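A few compounds are considered here, and "the series" means these few. Any claim that something is new, unique, unknown or untested is made for them only; others in the source may bear on it.

Compound 1 `CCOC(=O)CNC(C)(C)CC(=O)N[C@@H]1CCc2ccccc2N(Cc2ccc(-c3ccccc3-c3nn[nH]n3)cc2)C1=O` gives 56 nM in a functional assay (Pituitary gland cell) with Rattus norvegicus as the target; on this read-out lower numbers stand for an effect already at smaller amounts and higher numbers for an effect only at larger amounts of compound.
Compound 2 `CC(C)(CC(=O)N[C@@H]1CCc2ccccc2N(Cc2ccc(-c3ccccc3-c3nn[nH]n3)cc2)C1=O)NC[C@H](O)CO` gives 10 nM in this assay.

Compound 2 stands lowest of the two numbers, with compound 1 being the nearest and higher. Compound 3 `C[C@@H](O)CNC(C)(C)C(=O)N[C@@H]1CCc2ccccc2N(Cc2ccc(-c3ccccc3-c3nn[nH]n3)cc2)C1=O` differs from compound 2 by 1-((2-hydroxypropyl)amino)-1-methylethyl in place of 2-((2,3-dihydroxypropyl)amino)-2-methylpropyl on a carbonyl carbon. Going by the values given here, the only measured step, a 5.6-fold lower number from compound 1 to compound 2 (0.75 log units; beyond the scatter), also changed the group on the amine nitrogen, where a 1,2-dihydroxyethyl replaced an ethoxycarbonyl. The present change removes a hydroxyl and shortens the chain, so a small rise in this assay is expected, hardly beyond the scatter. Compound 3 is therefore estimated at 20 nM, between 7 nM and 60 nM, a step of a 2.0-fold higher number from compound 2 to compound 3 (0.30 log units; within the scatter).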

Compound 3, concentration for half-maximal effect: 300 nM
Beside the measured number, compound 3's estimate is 15-fold (1.18 log units) below it; measured number outside the range, above it.
By their numbers in this assay, from the lowest: compound 2; then compound 1; then compound 3.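

In this assay the group on the carbonyl carbon proves far more sensitive than the earlier step suggested: 1-((2-hydroxypropyl)amino)-1-methylethyl in place of 2-((2,3-dihydroxypropyl)amino)-2-methylpropyl gives a 30-fold higher number from compound 2 to compound 3 (1.48 log units; beyond the scatter) and outweighs the earlier gain. The same group also compares poorly with the ethoxycarbonyl-bearing chain, with a 5.4-fold higher number from compound 1 to compound 3 (0.73 log units; beyond the scatter) on that swap. No measured evidence accounts for this rise. The change alters chain length and hydroxyl count together, so their shares remain unseparated. The 1-((2,3-dihydroxypropyl)amino)-1-methylethyl group would isolate the chain length.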